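A few compounds are considered here, and "the series" means these few. Any claim that something is new, unique, unknown or untested is made for them only; others in the source may bear on it.

Measured compounds in an assay on Sf9 cells for inhibition of serine/threonine-protein kinase 4 (Homo sapiens), read by luminescence and ADP-Glo, with a stated time of 1 h, in the presence of a further agent that is not named here; a lower number here means a stronger inhibitor, a higher number a weaker inhibitor:
- compound 1, `CCCC1C(=O)N(C)c2cnc(Nc3ccc(S(N)(=O)=O)cc3)nc2N1C`: 206 nM
- compound 2, `CN1C(=O)C(c2cccc(F)c2)N(C)c2nc(Nc3ccc(S(N)(=O)=O)cc3)ncc21`: 134 nM
- compound 3, `CCc1ccccc1C1C(=O)N(C)c2cnc(Nc3ccc(S(N)(=O)=O)cc3)nc2N1C`: 51 nM

Compound 2 stands second highest of the three numbers, with compound 1 nearest at a step of a 1.5-fold lower number from compound 1 to compound 2 (0.19 log units; within the scatter) and compound 3 furthest at a 2.6-fold lower number from compound 2 to compound 3 (0.42 log units; beyond the scatter).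

Compound 4, `CN1C(=O)C(c2c(F)cccc2F)N(C)c2nc(Nc3ccc(S(N)(=O)=O)cc3)ncc21`, has not yet been measured in this assay. It differs from compound 2 in one place: 2,6-difluorophenyl in place of 3-fluorophenyl on a saturated ring carbon.

Going by the values given here, two measured steps bear on this change, since both alter the group on the same saturated ring carbon. The step of a 1.5-fold lower number from compound 1 to compound 2 (0.19 log units; within the scatter) was within the scatter, while a 2.6-fold lower number from compound 2 to compound 3 (0.42 log units; beyond the scatter) was a modest gain beyond it. Both fall in a narrow band, and neither swap matches the present one exactly, so compound 4 is expected to land close to compound 2, with at most a modest move, and the direction cannot be called with confidence. The expected step from compound 2 to compound 4 in this assay is a 1.3-fold lower number from compound 2 to compound 4 (0.13 log units; within the scatter). Compound 4 is thus estimated at 100 nM, within a range of 40 nM to 250 nM.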

Compound 4, half-maximal inhibitory concentration: 42 nM
Compound 4: the middle estimate sits 2.4-fold (0.38 log units) above what was measured; the measured number falls inside the stated range.
By their numbers in this assay, from the lowest: compounds 4 and 3 (each within the scatter of the next); then compounds 2 and 1 (each within the scatter of the next).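

In this assay, going by these compounds alone, replacing 3-fluorophenyl with 2,6-difluorophenyl on this saturated ring carbon gives a 3.2-fold lower number from compound 2 to compound 4 (0.50 log units; beyond the scatter), so the arrangement of fluorine on the phenyl ring can shift the number beyond the scatter, which the earlier compounds could not show. The change from the ethyl-bearing ring gives a 1.2-fold lower number from compound 3 to compound 4 (0.08 log units; within the scatter), so 2,6-difluorophenyl and 2-ethylphenyl are level here, and both stand apart from propyl, as a 4.9-fold lower number from compound 1 to compound 4 (0.69 log units; beyond the scatter) shows for the difluorophenyl group. No evidence is available to explain these differences.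

The compounds shown leave open whether a single fluorine, as in 2-fluorophenyl, would match 2,6-difluorophenyl. They also leave open how a ring containing nitrogen, such as pyridyl, or an amine on this carbon would compare.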